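A Pyrrole for a Phenyl on a Shared Core

This account rests on a few compounds, and the source may have more. Where it says the series, first, only, none or still open, it means among the compounds named here.

Of the compounds shown here, two on a shared core have been measured in a functional assay on HUVEC cells (Homo sapiens) for inhibition, read by ELISA; a lower number here means a stronger inhibitor, a higher number a weaker inhibitor. Compound 1, with the structure `COc1c(C)cnc(C[S+]([O-])c2nnc(-c3ccccc3)o2)c1C`, gives 7000 nM in this assay. Compound 2, with the structure `[O-][S+](Cc1ccccc1)c1nnc(-c2ccccn2)o1`, gives 5000 nM in this assay. Compound 1 has the highest of the two numbers, but its nearest neighbour, compound 2, lies within the usual scatter of it, so the two cannot be told apart.

Compound 3, with the structure `COc1c(C)cnc(C[S+]([O-])c2nnc(-c3cccn3C)o2)c1C`, is not yet measured. It differs from compound 1 in one place: 1-methyl-1H-pyrrol-2-yl in place of phenyl on an aromatic carbon. The new group sits on an aromatic carbon of a five-membered aromatic ring with 2 nitrogen and 1 oxygen. Within the data shown here, no measured pair shows what such a change does here, so no step beyond the scatter is expected from compound 1 to compound 3, with no change at the digits printed from compound 1 to compound 3 (within the scatter) as the expected step. Compound 3 is therefore estimated at 7000 nM in this assay, within a range from 2500 nM to 20000 nM.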

Compound 3, half-maximal inhibitory concentration: 6000 nM
The estimate for compound 3 lay 1.2-fold (0.07 log units) above the measured number; the range from low to high includes it.
By their numbers in this assay, from the lowest: compounds 2, 3 and 1 (each within the scatter of the next).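

In this assay, replacing phenyl with 1-methyl-1H-pyrrol-2-yl on the aromatic carbon of the five-membered ring gives a 1.2-fold lower number from compound 1 to compound 3 (0.07 log units; within the scatter). Among these compounds, this is the first direct one-place comparison at this position, and it shows that a six-membered all-carbon ring and a five-membered ring containing nitrogen can stand here without a readable difference, even though the entering group adds a hydrogen-bond acceptor to the count. No supporting measurement accounts for this result.

This single swap leaves open whether any group at this position can move the number beyond the scatter, such as a ring bearing an amine or a carboxylic acid, or a longer alkyl chain in place of the ring. It also leaves open what changes elsewhere on the shared core would do.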